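Removing the methoxy: compound 3 to compound 4

The source may hold more compounds than are shown below. What is called first, only, known or untested is meant among the compounds shown, and "the series" means these compounds.

Of the compounds shown here, three of the shared core have been measured: compound 1 `COc1cc(C2CC(c3cccc4ccccc34)=NN2C(C)=O)ccc1OCc1cn(Cc2ccc([N+](=O)[O-])cc2)nn1`, compound 2 `COc1cc(C2CC(c3ccc([N+](=O)[O-])cc3)=NN2C(C)=O)ccc1OCc1cn(Cc2ccc([N+](=O)[O-])cc2)nn1` and compound 3 `COc1ccc(C2CC(c3ccc(OCc4cn(Cc5ccc([N+](=O)[O-])cc5)nn4)cc3)=NN2C(C)=O)cc1`. Among the measured compounds shown here, in a functional assay on THP-1 cells (Homo sapiens) for inhibition, read by sulforhodamine B assay, tested at 100 uM (on this read-out higher numbers stand for more inhibition of growth at the one concentration tested and lower numbers for less inhibition of growth), compound 1 gives 79% and compound 2 gives 59%; the single one-point step in the set, a number 20 percentage points lower from compound 1 to compound 2 (beyond the scatter), is 4-nitrophenyl in place of naphthalen-1-yl on a carbon with a double bond to nitrogen. Compound 3 gives 26% in this assay, the lowest of the three numbers, beyond the scatter under both compound 2 and compound 1.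

Compound 4 `CC(=O)N1N=C(c2ccc(OCc3cn(Cc4ccc([N+](=O)[O-])cc4)nn3)cc2)CC1c1ccccc1` is not yet measured. Relative to compound 3 the change is hydrogen in place of methoxy on an aromatic carbon. For the measured compounds named here, no measured step alters this place; the step from compound 1 to compound 2 concerns a different part of the molecule and does not bear on it. With nothing to anchor a direction, the expected step of no change at the digits printed from compound 3 to compound 4 (within the scatter) is none beyond the scatter. Compound 4 is therefore estimated at 26% in this assay, with a range from 8% to 44%.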

Compound 4, percent growth inhibition at one concentration: 22%
Estimate against measurement, compound 4: 4 percentage points above; the measured number falls inside the stated range.
By their numbers in this assay, from the lowest: compounds 4 and 3 (each within the scatter of the next); then compound 2; then compound 1.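

In this assay, among the compounds shown here, the exchange of hydrogen for methoxy on an aromatic carbon, para to a large group, gives a number 4 percentage points lower from compound 3 to compound 4 (within the scatter) and so leaves no step at this place that can be told from the scatter. For the compounds shown here, this is the first reading at this place, and for this pair the 4-methoxyphenyl group can give way to phenyl with no step beyond the scatter, unlike the exchange at the other end of the molecule between compound 1 and compound 2. No measured evidence on this pair speaks to the reason for this reading.

Open, from the compounds shown here alone, is whether a dimethylamino group, a carboxylic acid or a longer chain such as butoxy at this carbon would give a step beyond the scatter. Also open, going by these compounds, is whether the same exchange would read alike with the naphthalen-1-yl group of compound 1 in the molecule.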